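Swapping a propyl chain for cyclopropyl on the shared core

The source may hold more compounds than are shown below. What is called first, only, known or untested is meant among the compounds shown, and "the series" means these compounds.

Of the compounds shown here, three built on the same core have been tested in a functional assay for agonist activity at Glucose-dependent insulinotropic receptor (Homo sapiens); on this read-out lower numbers stand for an effect already at smaller amounts and higher numbers for an effect only at larger amounts of compound. Compound 1 `Cc1noc(C2CCN(c3ncnc(Nc4ccc(S(C)(=O)=O)cc4)c3[N+](=O)[O-])CC2)n1` gives 260 nM, compound 2 `CCc1noc(C2CCN(c3ncnc(Nc4ccc(S(C)(=O)=O)cc4)c3[N+](=O)[O-])CC2)n1` gives 10 nM, and compound 3 `CCCc1noc(C2CCN(c3ncnc(Nc4ccc(S(C)(=O)=O)cc4)c3[N+](=O)[O-])CC2)n1` gives 430 nM. Compound 3 thus shows the highest of the three numbers; its value and that of compound 1 lie within the scatter, while the gap to compound 2 is large: a 43-fold higher number from compound 2 to compound 3 (1.63 log units; beyond the scatter).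

Compound 4 `CS(=O)(=O)c1ccc(Nc2ncnc(N3CCC(c4nc(C5CC5)no4)CC3)c2[N+](=O)[O-])cc1` differs from compound 3 in one place: cyclopropyl in place of propyl on an aromatic carbon. The earlier steps shown here at this position, a 26-fold lower number from compound 1 to compound 2 (1.41 log units; beyond the scatter) and a 1.7-fold higher number from compound 1 to compound 3 (0.22 log units; within the scatter), show that the read-out in this assay moves sharply with what is attached there, not steadily with chain length. None of them involves a ring, so the direction for cyclopropyl is uncertain; the most defensible expectation is a number somewhere between those of compound 2 and compound 3, meaning a moderate step down, a 4.3-fold lower number from compound 3 to compound 4 (0.63 log units; beyond the scatter). Compound 4 is therefore estimated at 100 nM, within a range of 15 nM to 600 nM.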

Compound 4, half-maximal effective concentration: 25 nM
Compound 4: the middle estimate sits 4.0-fold (0.60 log units) above what was measured; the measured number falls inside the stated range.
By their numbers in this assay, from the lowest: compound 2; then compound 4; then compounds 1 and 3 (each within the scatter of the next).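

Closing the three carbons of propyl into a cyclopropyl ring leaves the heavy-atom count unchanged but still makes a large difference (a 17-fold lower number from compound 3 to compound 4 (1.24 log units; beyond the scatter)), so at this position the arrangement of the carbons matters, not only their number. Cyclopropyl brings the number close to, but not level with, the lowest of the series, set by the ethyl compound (a 2.5-fold higher number from compound 2 to compound 4 (0.40 log units; beyond the scatter)), and it stands well clear of methyl (a 10-fold lower number from compound 1 to compound 4 (1.02 log units; beyond the scatter)). No measurement available here explains these differences.

The compounds shown leave open whether the closed ring itself counts or merely the branching at the attached carbon, a question that isopropyl could help separate. It is also unknown whether a larger ring such as cyclobutyl would keep the number low, or would instead behave like propyl.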